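Pyrazine Hydrazones: From Bromo to Dimethylamino

The source may report more compounds than this note shows. Statements on the series, on what has been measured and on what is new or still open speak of the compounds shown alone.

The series rests on a shared core carrying a benzylidene hydrazide, and two of its members have been measured for cytotoxicity. Compound 1 `O=C(N/N=C/c1ccccc1Br)c1cnccn1` bears a bromo group, and in an ADME assay on J774 cells (Mus musculus) for cytotoxicity, read by MTT assay, with a stated time of 48 h, tested at 50 ug/mL (on this read-out lower numbers stand for a stronger effect and higher numbers for a weaker effect at the one concentration tested), compound 1 gives 98%. Compound 2 `O=C(N/N=C/c1ccc(Br)cc1)c1cnccn1` carries its bromo group at a different position of the same ring, and in this assay compound 2 gives 100%, the higher of the two numbers, though the two values lie within the scatter of each other, so no order between them can be read.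

Compound 3 `CN(C)c1ccc(/C=N/NC(=O)c2cnccn2)cc1` has not yet been measured. It differs from compound 2 in one place: dimethylamino in place of bromo on an aromatic carbon. Nothing in the two measured values suggests that cell viability responds to the substituent on that ring, as both compounds leave the cells essentially unharmed. The step from compound 2 to compound 3 is therefore expected to be none beyond the scatter, at a number 3 percentage points lower from compound 2 to compound 3 (within the scatter). In this assay compound 3 is estimated to give 97%, within a range of 85% to 105%.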

Compound 3, a percentage reported as activity, at one concentration (the size of the read-out at that concentration, not a potency): 93%
Compound 3: middle estimate off by 4 percentage points, on the high side; low and high end bracket the measured number.
By their numbers in this assay, from the lowest: compounds 3, 1 and 2 (each within the scatter of the next).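

Among the compounds shown here, the step of a number 7 percentage points lower from compound 2 to compound 3 (within the scatter) in this assay is the first to exchange the substituent itself, since compounds 1 and 2 differ only in where the bromo group sits on the ring. On the six-membered aromatic ring, para to a large group, a single bromine atom gives way to dimethylamino, a group of 3 heavy atoms that brings 1 hydrogen-bond acceptor, and this step stays within the scatter, so compound 3 cannot be set apart from compound 2 and this one exchange gives no sign that the read-out responds to the group at this position. Nothing at hand bears on what lies behind this result.

From the compounds shown here alone, it remains open whether a carboxylic acid, a primary amine or a longer alkyl chain at the same position would move the number beyond the scatter, or whether it would stay as close as dimethylamino does. Also open, going by these compounds, is whether dimethylamino would behave the same way at the position that carries the bromo group in compound 1, and whether the core itself tolerates other changes.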